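This account rests on a few compounds, and the source may have more. Where it says the series, first, only, none or still open, it means among the compounds named here.

Three urea compounds have been tested in an ADME assay on HepG2 cells (Homo sapiens) for cytotoxicity, with a stated time of 72 h; a lower number here means that less compound is needed, a higher number that more compound is needed for the effect. Compound 1 `Cc1cc(NC(=O)Nc2ncccc2C)c2ccccc2n1` reaches only the limit of the measurement, giving > 25000 nM in this assay. Compound 2 `Cc1cc(NC(=O)Nc2ccccc2C(N)=O)c2ccccc2n1` likewise stops at that limit, with > 25000 nM. Compound 3 `COc1ccc(NC(=O)Nc2cc(C)nc3ccccc23)cc1Cl` also gives only a limit, > 25000 nM. Compound 1 therefore stands at the same limit as both others, since every one of the three sits at the limit of > 25000 nM in this assay, at which 3 of the 3 values shown sit. No numbered step between measured compounds is available here. Compound 4 `Cc1cc(NC(=O)Nc2cccc(F)c2)c2ccccc2n1` has not yet been measured; compared with compound 1 the change is 3-fluorophenyl in place of 3-methylpyridin-2-yl on an amide-type nitrogen. Given that compound 1 shows > 25000 nM, no change beyond the scatter is expected. The expected step is a step that the limit leaves unreadable from compound 1 to compound 4. Compound 4 is estimated to give about 30000 nM, between 15000 nM and 80000 nM.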

Compound 4, half-maximal effective concentration: > 25000 nM
Compound 4 gave a limit, no number (the forecaster's own chance of this, stated with the estimate: 85%); the middle value does not contradict the limit.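

In this assay, within the data shown here, compound 1 and compound 4 both give only a limit, and no step between them can be read. As far as these compounds go, what concentration any of the four compounds needs for the effect stays open.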